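The compounds below may be only part of what the source reports. "The series", "measured", "known", "first", "only" and "open" are said of these compounds alone.

Of the compounds shown here, three have been measured in a functional assay on MCF7 cells (Homo sapiens) for cytotoxicity, read by MTT assay, with a stated time of 72 h; a higher number here means a weaker inhibitor, a lower number a stronger inhibitor. Compound 1 `COc1ccc(/C=C2\CCC/C(=C\c3cccc(OC)c3OC)C2=O)cc1` gives 18600 nM. Compound 3 `COc1cc(/C=C2\CCC/C(=C\c3cccc(OC)c3OC)C2=O)cc(OC)c1` gives 1700 nM. Compound 2 `COc1ccc(/C=C2\CCC/C(=C\c3cccc(OC)c3OC)C2=O)c(OC)c1` reaches only a limit of the assay, reported as > 20000 nM.

Compound 1 and compound 2 share a core. The change between them is methoxy in place of hydrogen on an aromatic carbon. That change made an at least 1.0-fold higher number from compound 1 to compound 2 (0.03 log units; that floor lies within the scatter); the size of this step is known only as a floor because of the limit of > 20000 nM in this assay, at which 1 of the 3 values shown sits.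

Compound 3 has a different core from compound 1, and the difference between the two cores is not broken down here. Of the two numbers measured, compound 3 gives the lower one, and its gap to compound 1 lies beyond the usual scatter.

Compound 4 `COc1cccc(/C=C2\CCC/C(=C\c3cc(OC)c(OC)c(OC)c3)C2=O)c1OC` has not yet been measured. It differs from compound 3 by methoxy in place of hydrogen on an aromatic carbon. This is the same kind of change as from compound 1 to compound 2, but not the same: in the earlier case the carbon is ortho to a large group and meta to a methoxy group, whereas here it is ortho to two methoxy groups and para to a large group. For the measured compounds named here, the only measured step of this kind, an at least 1.0-fold higher number from compound 1 to compound 2 (0.03 log units; that floor lies within the scatter), stayed within the scatter, so a small step is expected here as well, namely a 1.1-fold lower number from compound 3 to compound 4 (0.05 log units; within the scatter). Compound 4 is therefore estimated at 1500 nM, with a likely range from 500 nM to 5000 nM.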

Compound 4, half-maximal inhibitory concentration: 1400 nM
Beside the measured number, compound 4's estimate is 1.1-fold (0.03 log units) above it; measured number inside the range.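

In this assay, placing a methoxy group on the aromatic carbon of compound 3 that is ortho to two methoxy groups and para to a large group gives a 1.2-fold lower number from compound 3 to compound 4 (0.08 log units; within the scatter), so on this core the change leaves the reading within the usual scatter. Set beside the earlier case, the comparison across the two cores can be made only in part: the same change on two cores in this assay, an at least 1.0-fold higher number (0.03 log units; that floor lies within the scatter) from compound 1 to compound 2 and a 1.2-fold lower number (0.08 log units; within the scatter) from compound 3 to compound 4; the limit leaves it open whether they differ. This does not show that the change behaves alike on both cores, as the methoxy group enters at a different place on the ring in each case, and the step to compound 2 is only a floor because the value of compound 2 is a limit of the assay: the limit of > 20000 nM in this assay, at which 1 of the 4 values shown sits.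

The compounds shown leave open whether a different group at the same carbon, such as an amine, a carboxylic acid or a longer chain, would move the number beyond the scatter, since only methoxy appears there. They also leave open what the same change would do on cores other than those of compound 1 and compound 3.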